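A few compounds are considered here, and "the series" means these few. Any claim that something is new, unique, unknown or untested is made for them only; others in the source may bear on it.

Compound 1 `CCNC(=O)N1CCC(Oc2cc3nccc(Oc4ccc(NC(=O)NN5C(=O)CSC5c5ccc(F)cc5)cc4)c3cc2OC)CC1` gives 2250 nM in a functional assay on HT-29 cells (Homo sapiens) for inhibition, read by MTT assay; on this read-out higher numbers stand for weaker inhibition and lower numbers for stronger inhibition. Among the compounds with values here, compound 2 `COc1cc2c(Oc3ccc(NC(=O)NN4C(=O)CSC4c4ccc(F)cc4)cc3)ccnc2cc1OC1CCN(C(=O)NC2CCCCC2)CC1` gives 3420 nM in this assay; the single step measured so far, a 1.5-fold higher number from compound 1 to compound 2 (0.18 log units; within the scatter), leaves the two compounds within the scatter of each other, so neither stands apart. Compound 3 `COc1cc2c(Oc3ccc(NC(=O)NN4C(=O)CSC4c4ccc(F)cc4)cc3)ccnc2cc1OC1CCN(C(=O)NCc2ccccc2)CC1` is not yet measured; it differs from compound 2 by benzyl in place of cyclohexyl on an amide-type nitrogen. Within the data shown here, the only step that bears on this position, a 1.5-fold higher number from compound 1 to compound 2 (0.18 log units; within the scatter), stayed inside the scatter, so no step beyond the scatter in either direction is expected in this assay. Compound 3 is therefore estimated at 3000 nM, between 1200 nM and 8000 nM. The expected step, a 1.1-fold lower number from compound 2 to compound 3 (0.06 log units; within the scatter), lies within the scatter.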

Compound 3, half-maximal inhibitory concentration: 6600 nM
For compound 3 the middle estimate is 2.2-fold (0.34 log units) below the measured one; low and high end bracket the measured number.
By their numbers in this assay, from the lowest: compounds 1, 2 and 3 (each within the scatter of the next, the first and the last beyond it).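

In this assay, within the data shown here, benzyl and cyclohexyl on the amide-type nitrogen cannot be told apart, a 1.9-fold higher number from compound 2 to compound 3 (0.29 log units; within the scatter), but benzyl against ethyl gives the first step at this position to clear the scatter, a 2.9-fold higher number from compound 1 to compound 3 (0.47 log units; beyond the scatter). The position therefore responds to its substituent, if only modestly, and compound 2 stays within the scatter of both neighbours. No evidence bears on the origin of this step.

Open, from the compounds shown here alone, is whether a longer chain, such as phenethyl, or a group carrying an amine or a carboxylic acid on this nitrogen would move the number in either direction. Also open, going by these compounds, is whether any group here can give a lower number than ethyl does in compound 1.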